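The source may report more compounds than this note shows. Statements on the series, on what has been measured and on what is new or still open speak of the compounds shown alone.

Measured so far in an assay on cells for inhibition of sodium/hydrogen exchanger (Oryctolagus cuniculus); a lower number here means a stronger inhibitor, a higher number a weaker inhibitor:
compound 1 `Cc1cc2c(cc1C(=O)N=C(N)N)S(=O)(=O)CCC2` gives 95 nM
compound 2 `CCC1(O)CS(=O)(=O)c2cc(C(=O)N=C(N)N)c(C)cc21` gives 34 nM
compound 3 `CCC1CS(=O)(=O)c2cc(C(=O)N=C(N)N)c(C)cc21` gives 24 nM

Among these three, compound 3 carries the lowest number; its gap to compound 1 is beyond the scatter, while compound 2 lies within the scatter of it. The unmeasured compound 4 `Cc1cc2c(cc1C(=O)N=C(N)N)S(=O)(=O)CC2N` differs from compound 3 by amino in place of ethyl on a saturated ring carbon. Among the measured compounds shown here, only one measured step touches that same ring carbon: a 1.4-fold lower number from compound 2 to compound 3 (0.15 log units; within the scatter), which shows little change when hydroxy was removed there. For the measured compounds named here, no measured step exchanges ethyl for amino. Compound 4 is therefore expected to stay near compound 3, with an estimated step of a 1.7-fold higher number from compound 3 to compound 4 (0.22 log units; within the scatter). Compound 4 is estimated at 40 nM, within 12 nM to 150 nM.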

Compound 4, half-maximal inhibitory concentration: 116 nM
Compound 4: the middle estimate sits 2.9-fold (0.46 log units) below what was measured; low and high end bracket the measured number.
By their numbers in this assay, from the lowest: compounds 3 and 2 (each within the scatter of the next); then compounds 1 and 4 (each within the scatter of the next).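

In this assay, the saturated ring carbon two ring bonds from the ring sulfur responds to what it carries: putting amino in place of ethyl gives a step beyond the scatter (a 4.8-fold higher number from compound 3 to compound 4 (0.68 log units; beyond the scatter)). The earlier exchange at this carbon, hydrogen in place of hydroxy, stayed within the scatter (a 1.4-fold lower number from compound 2 to compound 3 (0.15 log units; within the scatter)), so changes here are not all equally silent. Nothing available explains this difference. From the compounds shown here alone, whether the step follows from losing ethyl or from gaining amino remains open. A methyl group, a longer chain or a carboxylic acid on this carbon could separate the two.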